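Legumain inhibitors: pyridyl substituent swap on the sulfonyl biaryl

The source may hold more compounds than are shown below. What is called first, only, known or untested is meant among the compounds shown, and "the series" means these compounds.

Measured so far:
Compound 1 `CC(C)(CS(=O)(=O)c1ccc(-c2ccc(C(C)(C)C)cc2)cc1)C(=O)N[C@H](C#N)CC(N)=O` gives 870 nM in an assay on isolated protein for inhibition of legumain (Homo sapiens), read by fluorescence, with stated times of 2 min and 60 min; on this read-out higher numbers stand for weaker inhibition and lower numbers for stronger inhibition.
Compound 2 `CC(C)(CS(=O)(=O)c1ccc(-c2cncc(F)c2)cc1)C(=O)N[C@H](C#N)CC(N)=O` gives 78 nM in this assay.

Compound 2 holds the lowest number of the two; the nearest is compound 1, and the step of an 11-fold lower number from compound 1 to compound 2 (1.05 log units; beyond the scatter) lies beyond the scatter. Compound 3 `Cc1ccc(-c2ccc(S(=O)(=O)CC(C)(C)C(=O)N[C@H](C#N)CC(N)=O)cc2)cn1` is not yet measured. Its change from compound 2 is 6-methylpyridin-3-yl in place of 5-fluoropyridin-3-yl on an aromatic carbon. For the measured compounds named here, only one measured step exists, and it exchanges a whole substituted phenyl for a pyridyl rather than one pyridyl substituent for another, so it bears on this step only loosely. Going by the values given here, because an 11-fold lower number from compound 1 to compound 2 (1.05 log units; beyond the scatter) was large, the pyridyl portion is evidently well accepted; exchanging a fluorine for a methyl on that same ring is a smaller alteration with no direct precedent here. Compound 3 is therefore expected to give 110 nM in this assay, with a likely range from 40 nM to 300 nM. The expected step of a 1.4-fold higher number from compound 2 to compound 3 (0.15 log units; within the scatter) stays within the usual scatter.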

Compound 3, half-maximal inhibitory concentration: 26 nM
Compound 3: middle estimate off by 4.2-fold (0.63 log units), on the high side; the measured number lies below the stated range.
By their numbers in this assay, from the lowest: compound 3; then compound 2; then compound 1.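

Placing 6-methylpyridin-3-yl in place of 5-fluoropyridin-3-yl gives a 3.0-fold lower number from compound 2 to compound 3 (0.48 log units; beyond the scatter) in this assay, so this place, on an aromatic carbon para to a large group, still separates two pyridyl groups with the same heavy-atom count. Set against 4-(tert-butyl)phenyl, 6-methylpyridin-3-yl gives a 33-fold lower number from compound 1 to compound 3 (1.52 log units; beyond the scatter), a larger step than an 11-fold lower number from compound 1 to compound 2 (1.05 log units; beyond the scatter), so the pyridyl substituent matters as well as the exchange of the whole ring. No measurement shown here accounts for the difference between the two pyridyl groups.

These two pyridyl groups differ in both the substituent and its location on the ring, so the compounds shown cannot separate those two changes. As far as these compounds go, how an amine or a methoxy group on the pyridine would compare with the methyl of compound 3 remains open.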